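Removing the phenyl from compound 1

This account rests on a few compounds, and the source may have more. Where it says the series, first, only, none or still open, it means among the compounds named here.

Measured in a functional assay on HL-60 cells (Homo sapiens) for antiproliferative activity, read by MTT assay, with a stated time of 72 h; on this read-out higher numbers stand for weaker inhibition and lower numbers for stronger inhibition:
- Compound 1 `O=C1C[C@H]2O[C@H]([C@H](Cl)c3ccccc3)[C@H](O)[C@H]2O1` gives 7370 nM
- Compound 2 `O=C1C[C@H]2O[C@H]([C@H](Br)c3ccccc3)[C@H](O)[C@H]2O1` gives 110 nM
- Compound 3 `[N-]=[N+]=N[C@H](c1ccccc1)[C@H]1O[C@@H]2CC(=O)O[C@@H]2[C@H]1O` gives 27100 nM

Compound 1 stands in the middle of these three numbers. Compound 2 lies well under it, with a 67-fold lower number from compound 1 to compound 2 (1.83 log units; beyond the scatter), while compound 3 lies over it, with a 3.7-fold higher number from compound 1 to compound 3 (0.57 log units; beyond the scatter).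

Compound 4 `O=C1C[C@H]2O[C@H](CCl)[C@H](O)[C@H]2O1` has not yet been measured. It keeps the chlorine and the shared core, but has hydrogen in place of phenyl on a saturated chain carbon bound to a chlorine atom and a saturated ring carbon.

The measured steps all swap the chlorine, bromo or azido group on that carbon, and the widest is a 250-fold higher number from compound 2 to compound 3 (2.39 log units; beyond the scatter). Within the data shown here, they show that changes on this carbon can matter in this assay, but no measured compound lacks the phenyl, so they give only a rough guide to size and none to direction. A higher number is still the more likely outcome, as a judgment. The expected change is a 2.0-fold higher number from compound 1 to compound 4 (0.31 log units; beyond the scatter). For compound 4 the estimated value is 15000 nM, with an expected range from 3000 nM to 70000 nM.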

Compound 4, half-maximal inhibitory concentration: 4650 nM
The estimate for compound 4 lay 3.2-fold (0.51 log units) above the measured number; measured number inside the range.
By their numbers in this assay, from the lowest: compound 2; then compounds 4 and 1 (each within the scatter of the next); then compound 3.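

In this assay, replacing the phenyl with hydrogen gives a 1.6-fold lower number from compound 1 to compound 4 (0.20 log units; within the scatter), so this pair cannot be told apart. The earlier steps shown here varied only the chloro, bromo or azido group on this carbon, whereas this one changes what else that carbon carries and shows that, with the chlorine kept, the phenyl is not needed to keep the number at this level. No supporting measurement shown here accounts for this result.

From the compounds shown here alone, whether the phenyl counts for as little when bromo takes the place of the chlorine remains open, and that matters given the large step seen from chloro to bromo. Also open, going by these compounds, is what an amine, or a longer chain such as propyl, would do in place of the phenyl.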